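Fluoro in place of chloro on an aromatic carbon

A few compounds are considered here, and "the series" means these few. Any claim that something is new, unique, unknown or untested is made for them only; others in the source may bear on it.

compound 1 `Nc1nc(N)c2cc(CSC(=S)N3CCN(C4CCCCC4)CC3)ccc2n1` gives 5960 nM
compound 2 `Nc1nc(N)c2cc(CSC(=S)N3CCN(c4ccccc4)CC3)ccc2n1` gives 2840 nM
compound 3 `Nc1nc(N)c2cc(CSC(=S)N3CCN(c4ccc(Cl)cc4)CC3)ccc2n1` gives 6990 nM

In a functional assay on HeLa cells (Homo sapiens) for antiproliferative activity, read by MTT assay, with a stated time of 72 h (a higher number here means a weaker inhibitor, a lower number a stronger inhibitor), compound 3 reads 6990 nM and belongs to the upper pair of the three numbers. Nothing separates that pair, since the comparison is a 1.2-fold higher number from compound 1 to compound 3 (0.07 log units; within the scatter) and no more. The gap to the remaining compound is modest but beyond the scatter, as a 2.5-fold higher number from compound 2 to compound 3 (0.39 log units; beyond the scatter) shows.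

Compound 4 `Nc1nc(N)c2cc(CSC(=S)N3CCN(c4ccc(F)cc4)CC3)ccc2n1` has fluoro in place of chloro on an aromatic carbon, para to a large group, which counts up as fluoro in place of chloro on an aromatic carbon in all. Among the measured compounds shown here, no measured compound carries fluoro, so no step shows this change directly. The nearest evidence is a 2.5-fold higher number from compound 2 to compound 3 (0.39 log units; beyond the scatter) for chloro in place of hydrogen on an aromatic carbon, a modest step. The step of a 2.1-fold lower number from compound 1 to compound 2 (0.32 log units; beyond the scatter) concerns phenyl in place of cyclohexyl and bears on this change only weakly.

Compound 4 is therefore expected to land between the readings of compound 2 and compound 3, with a small move toward a lower number and no large change. The expected step is a 1.6-fold lower number from compound 3 to compound 4 (0.19 log units; within the scatter) in this estimate. For compound 4 the estimated value is 4500 nM with an expected range from 2200 nM to 9000 nM in this assay terms.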

Compound 4, half-maximal inhibitory concentration: 1840 nM
The estimate for compound 4 lay 2.4-fold (0.39 log units) above the measured number; the whole stated range lies above it.
By their numbers in this assay, from the lowest: compounds 4 and 2 (each within the scatter of the next); then compounds 1 and 3 (each within the scatter of the next).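

In this assay, this place on the aromatic ring, para to a large group, responds to which halogen sits there and not merely to the presence of a halogen, with fluoro in place of chloro giving a 3.8-fold lower number from compound 3 to compound 4 (0.58 log units; beyond the scatter), a modest step. Fluoro in place of hydrogen gives a 1.5-fold lower number from compound 2 to compound 4 (0.19 log units; within the scatter), which is within the scatter, whereas chloro in place of hydrogen gives a 2.5-fold higher number from compound 2 to compound 3 (0.39 log units; beyond the scatter), so among the compounds shown only chloro separates from the plain phenyl compound. Against cyclohexyl, 4-fluorophenyl gives a 3.2-fold lower number from compound 1 to compound 4 (0.51 log units; beyond the scatter) and phenyl gives a 2.1-fold lower number from compound 1 to compound 2 (0.32 log units; beyond the scatter), both modest steps, but compound 3 goes against any general rule for aryl groups on this nitrogen, since its step of a 1.2-fold higher number from compound 1 to compound 3 (0.07 log units; within the scatter) stays within the scatter.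

Nothing available here explains why fluoro and chloro part in this way. From the compounds shown here alone, whether bromo, methyl, methoxy or trifluoromethyl in the same place would read with compound 2 and compound 4 or with compound 3 remains open, so two halogens cannot yet be taken as a trend.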